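This account rests on a few compounds, and the source may have more. Where it says the series, first, only, none or still open, it means among the compounds named here.

Measured compounds:
compound 1 `O=C(Nc1ccccc1O)C1CCc2ccccc2N1C(=O)c1ccc(Cl)cc1`, 19600 nM
compound 2 `O=C(Nc1ccccc1C(F)(F)F)C1CCc2ccccc2N1C(=O)c1ccc(Cl)cc1`, 824 nM

In a functional assay on ACHN cells (Homo sapiens) for cytotoxicity, read by sulforhodamine B assay, with a stated time of 72 h (a higher number here means a weaker inhibitor of growth, a lower number a stronger inhibitor of growth), compound 1 stands at the highest of the two numbers; its nearest neighbour is compound 2, and the change a 24-fold lower number from compound 1 to compound 2 (1.38 log units; beyond the scatter) is hydrogen bonding replaced by trifluoromethyl on the anilide ring. Compound 3 `O=C(Nc1ccccc1O)C1CCc2ccccc2N1C(=O)c1ccccc1` differs from compound 1 by hydrogen in place of chloro on an aromatic carbon, a change on the other aromatic ring. Within the data shown here, no measured step touches that ring, so nothing here predicts a shift beyond the scatter. Compound 3 is therefore expected to show roughly a 1.3-fold higher number from compound 1 to compound 3 (0.11 log units; within the scatter), giving an estimate of 25000 nM with a range from 8000 nM to 80000 nM.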

Compound 3, concentration for 50% growth inhibition: 4260 nM
The estimate for compound 3 lay 5.9-fold (0.77 log units) above the measured number, outside the stated range (below it).
By their numbers in this assay, from the lowest: compound 2; then compound 3; then compound 1.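

Taking the chloro off the 4-chlorophenyl group matters: the step to the plain phenyl gives a 4.6-fold lower number from compound 1 to compound 3 (0.66 log units; beyond the scatter). This shows that the position para to a large group on this ring also affects growth inhibition, whereas the earlier step showed a change only on the other aromatic ring. Nothing available explains why this step goes in this direction.

As far as these compounds go, whether fluoro or methoxy at this position would give a lower or higher number remains open. So does whether hydrogen in place of chloro has a similar effect when trifluoromethyl replaces the hydroxy.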